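The source may hold more compounds than are shown below. What is called first, only, known or untested is meant among the compounds shown, and "the series" means these compounds.

In a functional assay, with a stated time of 20 min, tested at 0.5 mg/mL (a lower number here means a weaker effect, a higher number a stronger effect of the compound at the concentration tested), compound 1 `CC(C)[C@@H]1CC[C@@H](C)C[C@@]12N(C)C(=O)[C@@H]1[C@H]3C(=O)NC(=O)[C@H]3ON12` gives 21.6%. Compound 2 `CC(C)[C@@H]1CC[C@@H](C)C[C@@]12N(C)C(=O)[C@@H]1[C@H]3C(=O)N(C)C(=O)[C@H]3ON12` gives 18.2% in this assay, and the step of a number 3.4 percentage points lower from compound 1 to compound 2 (within the scatter) places the two compounds within the scatter of each other, so compound 2 stands with compound 1 rather than apart from it.

Compound 3 `CC(C)[C@@H]1CC[C@@H](C)C[C@@]12N(C)C(=O)[C@@H]1[C@H]3C(=O)N(c4ccccc4)C(=O)[C@H]3ON12` has not been measured. It differs from compound 2 in one place: phenyl in place of methyl on an amide-type nitrogen in a ring. Going by the values given here, the only measured step that bears on this site is a number 3.4 percentage points lower from compound 1 to compound 2 (within the scatter), which shows that replacing the hydrogen with a methyl on this amide-type nitrogen left the read-out within the scatter. Among the compounds with values here, no measured step shows a phenyl entering at this position, so the size of the step is open. Compound 3 is therefore expected to lie near compound 2, with the estimated step of a number 0.2 percentage points lower from compound 2 to compound 3 (within the scatter) not beyond the scatter. The estimate for compound 3 in this assay is 18%, within 5% to 35%.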

Compound 3, a percentage reported as activity, at one concentration (the size of the read-out at that concentration, not a potency): 21.6%
Compound 3: middle estimate off by 3.6 percentage points, on the low side, within the range that was stated.
By their numbers in this assay, from the lowest: compounds 2, 1 and 3 (each within the scatter of the next).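

In this assay, phenyl in place of methyl on the amide-type nitrogen in a ring gives a number 3.4 percentage points higher from compound 2 to compound 3 (within the scatter), and phenyl in place of hydrogen gives no change at the digits printed from compound 1 to compound 3 (within the scatter). Going by these compounds alone, this nitrogen therefore carries hydrogen, methyl or phenyl with all three read-outs within the scatter of each other, something the single step from hydrogen to methyl could not show for a group with an aromatic ring. No evidence is at hand that would explain this reading.

The compounds shown leave open whether a group of another kind on this nitrogen, such as an amine or a carboxylic acid on a longer chain, would move the read-out beyond the scatter. On these data alone, every change shown sits at this one position, so the effect of changes elsewhere on the shared core also remains open.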